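Replacing the indanyl amine substituent with an acetamidobenzyl group

A few compounds are considered here, and "the series" means these few. Any claim that something is new, unique, unknown or untested is made for them only; others in the source may bear on it.

In an assay on CHO cells for displacement of a labelled ligand from 5-hydroxytryptamine receptor 1D (Homo sapiens) (a lower number here means a stronger inhibitor, a higher number a weaker inhibitor), compound 3 `c1ccc2c(c1)CCC2NCC1CCN(CCCc2c[nH]c3ccc(-n4cnnc4)cc23)CC1` gives 1.1 nM. Compound 1 `CC(=O)Nc1ccc([C@@H](C)NCC2CCN(CCCc3c[nH]c4ccc(-n5cnnc5)cc34)CC2)cc1` gives 1.5 nM and compound 2 `c1ccc(NCC2CCN(CCCc3c[nH]c4ccc(-n5cnnc5)cc34)CC2)nc1` gives 1.7 nM, so compound 3 is not separated from either: a 1.4-fold lower number from compound 1 to compound 3 (0.13 log units; within the scatter) and a 1.5-fold lower number from compound 2 to compound 3 (0.19 log units; within the scatter). Compound 4 `CC(=O)Nc1ccc(CNCC2CCN(CCCc3c[nH]c4ccc(-n5cnnc5)cc34)CC2)cc1` carries 4-acetamidobenzyl in place of 2,3-dihydro-1H-inden-1-yl on an amine nitrogen. Within the data shown here, no measured step covers exactly this exchange; the nearest is compound 1, which bears the same acetamidophenyl amide on the amine nitrogen with one extra methyl, and a 1.4-fold lower number from compound 1 to compound 3 (0.13 log units; within the scatter) is within the scatter, as is a 1.1-fold higher number from compound 1 to compound 2 (0.05 log units; within the scatter). All three substituents on this amine therefore give numbers in this assay that cannot be told apart, and no step beyond the scatter is expected for a 1.6-fold higher number from compound 3 to compound 4 (0.21 log units; within the scatter). Compound 4 is estimated at 1.8 nM, with a range of 0.7 nM to 4.5 nM.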

Compound 4, half-maximal inhibitory concentration: 4.2 nM
Beside the measured number, compound 4's estimate is 2.3-fold (0.37 log units) below it, and the stated range covers the measured number.
By their numbers in this assay, from the lowest: compounds 3, 1 and 2 (each within the scatter of the next); then compound 4.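

In this assay, among these compounds, the amine substituent no longer looks silent: a 3.8-fold higher number from compound 3 to compound 4 (0.58 log units; beyond the scatter) and a 2.5-fold higher number from compound 2 to compound 4 (0.39 log units; beyond the scatter) are the first steps at this position beyond the scatter, both modest. The single-place reading is a 2.8-fold higher number from compound 1 to compound 4 (0.45 log units; beyond the scatter) for hydrogen in place of methyl on a saturated chain carbon bound to an amine nitrogen and an aromatic carbon, a change that leaves the scatter as no exchange among compounds 1, 2 and 3 did. No evidence on hand accounts for these steps.

From the compounds shown here alone, whether an ethyl group on that carbon would keep the number of compound 1 stays open, as does the effect of a carboxylic acid in place of the acetamido group.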